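Moving the Nitro Group in a Thiourea Series

A few compounds are considered here, and "the series" means these few. Any claim that something is new, unique, unknown or untested is made for them only; others in the source may bear on it.

Three compounds were measured in a functional assay on HL-60 cells (Homo sapiens) for inhibition, read by CCK-8 assay, with a stated time of 48 h; a lower number here means a stronger inhibitor, a higher number a weaker inhibitor:

- compound 1, `COc1ccc(Oc2ccc(C(C)C)cc2-c2ccsc2S(=O)(=O)NCCNC(=O)Nc2cc(Cl)cc(Cl)c2)cc1OC`: compound 1 gives 6500 nM
- compound 2, `Cc1ccc(-c2ccsc2S(=O)(=O)NCCNC(=S)Nc2ccc([N+](=O)[O-])cc2)c(Oc2ccc(O)c(O)c2)c1`: compound 2 gives 2900 nM
- compound 3, `O=S(=O)(NCCNC(=S)Nc1cc(C(F)(F)F)cc(C(F)(F)F)c1)c1ccc(-c2ccccc2Oc2ccc(O)c(O)c2)s1`: compound 3 gives 18300 nM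

Compound 2 stands lowest of the three numbers in this assay, and both gaps lie beyond the usual scatter: compound 1 is the nearest and compound 3 the furthest, so compound 2 is the most potent of the measured set. The three differ in several places at once, so no single structural step can be read off among them.

Compound 4, `Cc1ccc(-c2ccsc2S(=O)(=O)NCCNC(=S)Nc2cccc([N+](=O)[O-])c2)c(Oc2ccc(O)c(O)c2)c1`, is not yet measured. It differs from compound 2 in one place: 3-nitrophenyl in place of 4-nitrophenyl on an amide-type nitrogen. Among the measured compounds shown here, the two compounds have the same atoms, joined differently, and nothing among the measured compounds shows how such a change behaves here. In the absence of any comparable step, the number for compound 4 in this assay is expected to sit close to that of compound 2, with the step of a 1.2-fold higher number from compound 2 to compound 4 (0.08 log units; within the scatter) estimated to stay within the scatter. Compound 4 is accordingly estimated at 3500 nM, in a range from 1200 nM to 10000 nM.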

Compound 4, half-maximal inhibitory concentration: 3400 nM
For compound 4 the middle estimate is 1.0-fold (0.01 log units) above the measured one; the measured number falls inside the stated range.
By their numbers in this assay, from the lowest: compounds 2, 4 and 1 (each within the scatter of the next, the first and the last beyond it); then compound 3.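

In this assay, among the compounds shown here, 3-nitrophenyl in place of 4-nitrophenyl on an amide-type nitrogen gives a 1.2-fold higher number from compound 2 to compound 4 (0.07 log units; within the scatter), and this is the only step in the set that changes a single place. For the compounds shown here, it shows that, on this thiocarbonyl-bound nitrogen and with the rest of the molecule held constant, the two arrangements of the same atoms cannot be told apart in this assay, something the earlier compounds, which differ in several places at once, could not show. No measurement bears on why the two compounds read alike.

From the compounds shown here alone, whether a nitrile, an amine or a carboxylic acid in place of the nitro group would also stay within the scatter remains open. So does whether the same shift of the nitro group would behave alike with a carbonyl in place of the thiocarbonyl.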